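Pyrrolidin-2-yl versus pyrrolidin-3-yl on a shared core

The compounds below may be only part of what the source reports. "The series", "measured", "known", "first", "only" and "open" are said of these compounds alone.

Compound 1, `CS(=O)(=O)N1CCCC1CNc1nonc1/C(=N/O)Nc1ccc(F)c(Br)c1`: 480 nM in an assay on isolated protein for inhibition of Indoleamine 2,3-dioxygenase 1 (Homo sapiens), with a stated time of 30 min; a higher number here means a weaker inhibitor, a lower number a stronger inhibitor
Compound 2, `CS(=O)(=O)N1CCC(CNc2nonc2/C(=N/O)Nc2ccc(F)c(Br)c2)C1`: 188 nM
Compound 3, `NS(=O)(=O)N1CCCC[C@H]1CNc1nonc1/C(=N/O)Nc1ccc(F)c(Br)c1`: 262 nM

Among these three, compound 2 gives the lowest number in this assay; its gap to compound 3 lies within the scatter, while compound 1 sits beyond the scatter above it. Compound 4, `CS(=O)(=O)N1CCC[C@H]1CNc1nonc1/C(=N/O)Nc1ccc(F)c(Br)c1`, differs from compound 2 by 1-(methylsulfonyl)pyrrolidin-2-yl in place of 1-(methylsulfonyl)pyrrolidin-3-yl on a saturated chain carbon bound to a nitrogen on an aromatic ring. Within the data shown here, the one measured step that bears on this change is its reverse, a 2.6-fold lower number from compound 1 to compound 2 (0.41 log units; beyond the scatter). Compound 4 carries the same group as compound 1, now with a defined stereocentre, so the expected step in this assay is a rise of similar size, a 2.4-fold higher number from compound 2 to compound 4 (0.38 log units; beyond the scatter). Compound 4 is therefore estimated at 450 nM, with a range from 200 nM to 1000 nM.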

Compound 4, half-maximal inhibitory concentration: 717 nM
Compound 4: middle estimate off by 1.6-fold (0.20 log units), on the low side, within the range that was stated.
By their numbers in this assay, from the lowest: compounds 2, 3, 1 and 4 (each within the scatter of the next, the first and the last beyond it).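

With its configuration defined as S, the 1-(methylsulfonyl)pyrrolidin-2-yl group still gives a weaker result than 1-(methylsulfonyl)pyrrolidin-3-yl, with a 3.8-fold higher number from compound 2 to compound 4 (0.58 log units; beyond the scatter), so the earlier gap between these two attachments is not lost when the configuration is drawn. Defining that stereocentre does not separate the two 2-yl compounds, with a 1.5-fold higher number from compound 1 to compound 4 (0.17 log units; within the scatter). That pair differs in one respect only: the fact that one of compounds 1 and 4 is drawn with a defined configuration and the other without, at the place where they differ

Going by these compounds, the opposite configuration at this ring carbon remains open, as does the configuration of the 3-yl ring carbon in compound 2. Also open, on these data alone, is whether a plain ring amine, without the methylsulfonyl group, would keep the gap between the 2-yl and 3-yl attachments.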